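Swapping one group after two limit readings

A few compounds are considered here, and "the series" means these few. Any claim that something is new, unique, unknown or untested is made for them only; others in the source may bear on it.

Compound 1 `Cc1c(-c2ccc(-c3ccccc3F)cc2)nc2ccc(F)cc2c1C(F)F`: > 3000 nM
Compound 2 `Cc1c(-c2ccc(-c3ccccc3F)cc2)nc2ccc(F)cc2c1C(=O)C(F)(F)F`: > 3000 nM

Both entries are limits rather than numbers in a functional assay on MOLM-13 cells (Homo sapiens) for antiproliferative activity (on this read-out higher numbers stand for weaker inhibition and lower numbers for stronger inhibition), and both compounds sit at the limit of > 3000 nM in this assay, at which 2 of the 2 values shown sit. Within the data shown here, the one measured change is a step that the two limits leave unreadable from compound 1 to compound 2, so it offers no size to build on.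

Compound 2 stands only at a limit, > 3000 nM.

Compound 3 `Cc1c(-c2ccc(-c3ccccc3F)cc2)nc2ccc(F)cc2c1-c1noc(=O)[nH]1` keeps the shared core and changes one group, on an aromatic carbon opposite the ring nitrogen: a group of 6 heavy atoms (2 carbon, 2 nitrogen, 2 oxygen; one five-membered aromatic ring with 3 hetero atoms) in place of a group of 6 heavy atoms (2 carbon, 1 oxygen, 3 fluorine; no ring), on an aromatic carbon. The new group, with its five-membered aromatic ring, has not been tested on this core, so the expectation is loose. A move toward stronger inhibition is expected, though compound 3 may well stay at a limit too. The expected change is an at least 3.7-fold lower number from compound 2 to compound 3 (0.57 log units; beyond the scatter). For compound 3 the estimated value is 800 nM, with an expected range of 80 nM to 4000 nM.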

Compound 3, half-maximal inhibitory concentration: > 3000 nM
Compound 3: a limit, no number; the forecaster's own chance of this, stated with the estimate: 35%; at least 3.7-fold (0.57 log units) between middle value and limit.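

Compound 3 gives a limit and not a number: > 3000 nM. Among these compounds, no step among compound 1, compound 2 and compound 3 can be read. The compounds shown leave open how strongly each one inhibits, and whether swapping this group on the shared core changes that at all.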